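Changing the Amine on Compound 3

The source may hold more compounds than are shown below. What is called first, only, known or untested is meant among the compounds shown, and "the series" means these compounds.

Three compounds share one core and the same dibutylamino end, differing only in a small chain on that core: compound 1 `CCCCc1cn2ccccc2c1S(=O)(=O)c1ccc(OCCCN(CCCC)CCCC)cc1`, compound 2 `CCCCN(CCCC)CCCOc1ccc(S(=O)(=O)c2c(C)cn3ccccc23)cc1` and compound 3 `CCCCN(CCCC)CCCOc1ccc(S(=O)(=O)c2c(CC)cn3ccccc23)cc1`. In a functional assay (aorta) with Rattus norvegicus as the target (on this read-out lower numbers stand for stronger inhibition and higher numbers for weaker inhibition), compound 1 gives 284 nM, compound 2 gives 162 nM and compound 3 gives 31.3 nM, the lowest number of the three. The small chain alone accounts for a 1.8-fold lower number from compound 1 to compound 2 (0.24 log units; within the scatter), for a 5.2-fold lower number from compound 2 to compound 3 (0.71 log units; beyond the scatter) and for a 9.1-fold lower number from compound 1 to compound 3 (0.96 log units; beyond the scatter).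

Compound 4 `CCc1cn2ccccc2c1S(=O)(=O)c1ccc(OCCCNC(C)(C)C)cc1` departs from compound 3 in one place: (tert-butyl)amino in place of dibutylamino on a saturated chain carbon, three bonds along the chain from an oxygen on an aromatic ring. Among the measured compounds shown here, none of the measured steps touches this amine, so they bear on the change only indirectly. They show how far an edit elsewhere on these molecules moved the number, and even the largest of them, a 9.1-fold lower number from compound 1 to compound 3 (0.96 log units; beyond the scatter), is modest. For the measured compounds named here, with no direct precedent, a modest step towards a higher number in this assay is expected, though the direction is far from certain. The estimate amounts to an expected 3.5-fold higher number from compound 3 to compound 4 (0.55 log units; beyond the scatter). For compound 4 the expected value is 110 nM, with an estimated range from 20 nM to 600 nM.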

Compound 4, half-maximal inhibitory concentration: 413 nM
For compound 4 the middle estimate is 3.8-fold (0.57 log units) below the measured one; measured number inside the range.
By their numbers in this assay, from the lowest: compound 3; then compounds 2, 1 and 4 (each within the scatter of the next, the first and the last beyond it).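

The amine end, held fixed in compounds 1 to 3, turns out to be a sensitive place: in this assay, (tert-butyl)amino in place of dibutylamino gives a 13-fold higher number from compound 3 to compound 4 (1.12 log units; beyond the scatter), a step of large size, whereas the steps on the small chain were modest or within the scatter. This single edit changes two counted features together, since the group entering has fewer heavy atoms (5 against 9) and brings a hydrogen-bond donor that dibutylamino lacks, so the step cannot be assigned to either one alone. Nothing in the available data explains why the number rose.

A group such as diethylamino, which is smaller than dibutylamino but has no hydrogen on its nitrogen, or n-butylamino, which keeps one butyl chain and has such a hydrogen, would help to pull those two features apart, and a ring amine such as piperidine would add a further shape to the comparison. Going by these compounds, it also remains open whether (tert-butyl)amino has a similar effect when the small chain on the core is methyl or butyl rather than ethyl.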